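A few compounds are considered here, and "the series" means these few. Any claim that something is new, unique, unknown or untested is made for them only; others in the source may bear on it.

Measured compounds:
- Compound 1 `CC(=O)O[C@@H]1OC(=O)[C@](C)(C(C)=O)[C@@H]1C` gives 6000 nM in a functional assay on MCF7 cells (Homo sapiens) for cytotoxicity, read by MTT assay; a higher number here means a weaker inhibitor, a lower number a stronger inhibitor.
- Compound 2 `CC(=O)O[C@@H]1OC(=O)[C@@](C(C)=O)(C2SCCCS2)[C@@H]1C` reaches only a limit of the assay, > 50000 nM, in this assay.
- Compound 3 `CC(=O)O[C@@H]1OC(=O)[C@](O)(C(C)=O)[C@@H]1C` likewise reaches only a limit, > 50000 nM, in this assay.

Going by the values given here, compound 1 is therefore the only compound of the three with a real number; the other two sit at the limit of > 50000 nM in this assay, at which 2 of the 3 values shown sit. The step to be followed leads from compound 1 to compound 4 `CC(=O)O[C@@H]1OC(=O)[C@](C)(C(C)=O)[C@@H]1C(C)C`, whose change is isopropyl in place of methyl on a saturated ring carbon, an isopropyl in place of a methyl on a saturated ring carbon of the shared core.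

Two measured steps start from compound 1, both at a saturated ring carbon: an at least 8.3-fold higher number from compound 1 to compound 2 (0.92 log units; beyond the scatter) and an at least 8.3-fold higher number from compound 1 to compound 3 (0.92 log units; beyond the scatter). Each replacement at the core weakened the compound well beyond the scatter. The change in compound 4 is smaller than either of these, a simple enlargement of a carbon group, so a milder step is expected, estimated as a 1.7-fold higher number from compound 1 to compound 4 (0.22 log units; within the scatter). Compound 4 is thus estimated at 10000 nM in this assay, within a range from 3000 nM to 40000 nM.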

Compound 4, half-maximal inhibitory concentration: > 50000 nM
Compound 4: a limit, no number (the forecaster's own chance of this, stated with the estimate: 25%); middle value at least 5.0-fold (0.69 log units) from the limit.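

Going by these compounds alone, this position turns out to be sensitive as well: the earlier steps changed a different ring carbon, whereas here the change sits on the saturated ring carbon two ring bonds from the ring oxygen. Adding only carbon, as isopropyl in place of methyl, gives an at least 8.3-fold higher number from compound 1 to compound 4 (0.92 log units; beyond the scatter), so even a change that enters no ring and no hydrogen-bond donors or acceptors costs activity in this assay. Among the compounds shown, only compound 1 keeps a real number, and every change from it ends at the same limit of the assay: the limit of > 50000 nM in this assay, at which 3 of the 4 values shown sit.

As far as these compounds go, how far the activity falls for compound 4 remains unknown, as a limit gives no exact number. Also open, from the compounds shown here alone, is whether a hydrogen or an ethyl at this ring carbon, in place of the methyl of compound 1, would still give a real number.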